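This account rests on a few compounds, and the source may have more. Where it says the series, first, only, none or still open, it means among the compounds named here.

Measured compounds:
compound 1 `COc1cc(-c2nnc(SCc3ccc([N+](=O)[O-])cc3)o2)ccc1O`, 688000 nM in an ADME assay on cells (Mus musculus, strain BALB/c) for cytotoxicity, read by MTT assay, with a stated time of 24 h; on this read-out lower numbers stand for higher toxicity in this test and higher numbers for lower toxicity in this test
compound 2 `COc1cc(-c2nnc(SCc3ccccc3)o2)ccc1O`, 211000 nM in this assay

Compound 2 gives the lowest of the two numbers in this assay, and the step of a 3.3-fold lower number from compound 1 to compound 2 (0.51 log units; beyond the scatter) separates it from compound 1. Compound 3 `COc1cc(-c2nnc(SCc3ccccc3)o2)ccc1OCc1ccccc1` is not yet measured. It differs from compound 2 by benzyl in place of hydrogen on an oxygen on an aromatic ring. Within the data shown here, the only measured step, a 3.3-fold lower number from compound 1 to compound 2 (0.51 log units; beyond the scatter), concerns a change at a different part of the molecule, so no measured step bears directly on the change from compound 2 to compound 3. With nothing to lean on, the expectation for compound 3 is a step of a 1.2-fold lower number from compound 2 to compound 3 (0.07 log units; within the scatter) in this assay, that is, no change beyond the scatter, and a wide range around it. The estimate for compound 3 in this assay is 180000 nM, expected to fall between 60000 nM and 500000 nM.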

Compound 3, half-maximal cytotoxic concentration: 197000 nM
Beside the measured number, compound 3's estimate is 1.1-fold (0.04 log units) below it; the measured number falls inside the stated range.
By their numbers in this assay, from the lowest: compounds 3 and 2 (each within the scatter of the next); then compound 1.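

Putting benzyl in place of hydrogen on an oxygen on an aromatic ring, which turns hydroxy into benzyloxy, gives a 1.1-fold lower number from compound 2 to compound 3 (0.03 log units; within the scatter) in this assay. Among these compounds, the earlier compounds left this oxygen unchanged, and their only step, a 3.3-fold lower number from compound 1 to compound 2 (0.51 log units; beyond the scatter), came from a different part of the molecule, so this is the first sign that the oxygen can carry a group of 7 heavy atoms without a shift beyond the scatter in this test. No supporting data are available to explain this result.

From the compounds shown here alone, whether an amine, a carboxylic acid or a longer chain on this oxygen would read the same remains open. Also open, going by these compounds, is whether exchanging nitro for hydrogen would give a similar step in compounds that carry benzyloxy.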